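The compounds below may be only part of what the source reports. "The series", "measured", "known", "first", "only" and "open" are said of these compounds alone.

Measured compounds:
Compound 1, `C[C@@]1(c2ccc(OC(F)(F)F)cc2)C[C@@](O)(c2ccccn2)CO1`: 66.7 mL/min/kg
Compound 2, `O[C@H](c1ccccn1)[C@]1(c2cc(C(F)(F)F)ccn2)C[C@@H](O)C1`: 33.3 mL/min/kg

In an ADME assay on liver for metabolic stability, with Liver microsome (Homo sapiens) as the target, read by LC-MS, using microsomes, with a stated time of 5 h (a lower number here means slower removal, a higher number faster removal of the compound), compound 1 gives 66.7 mL/min/kg and compound 2 gives 33.3 mL/min/kg; the two numbers lie within the usual scatter of each other, so nothing separates them. Compound 3, `C[C@]1(c2ccc(OC(F)(F)F)cc2)C[C@](O)(c2ccccn2)CO1`, is not yet measured. Its relation to compound 1 is the two compounds have the same atoms and bonds and differ only in configuration as drawn: 2 of 2 stereo elements differ (all stereocentres are inverted: mirror images); a stereocentre at a saturated ring carbon is drawn S in compound 1 and R in compound 3; a stereocentre at a saturated ring carbon is drawn R in compound 1 and S in compound 3. For the measured compounds named here, no step between mirror images has been measured here, so there is nothing to lean on; a change of no size beyond the scatter is expected, with the step estimated as a 1.1-fold lower number from compound 1 to compound 3 (0.05 log units; within the scatter). Compound 3 is expected to give about 60 mL/min/kg, within 30 mL/min/kg to 120 mL/min/kg.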

Compound 3, clearance: 117 mL/min/kg
Compound 3: middle estimate off by 2.0-fold (0.29 log units), on the low side; the range from low to high includes it.
By their numbers in this assay, from the lowest: compounds 2, 1 and 3 (each within the scatter of the next, the first and the last beyond it).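

For the compounds shown here, compounds 1 and 3 are the first measured mirror-image pair, and in this assay the step is a 1.8-fold higher number from compound 1 to compound 3 (0.24 log units; within the scatter). Inverting both stereocentres at the saturated ring carbons therefore moves the clearance no further than repeat measurements would, so this pair gives no sign that the drawn configuration matters here. The comparison has nothing else mixed into it: the fact that compounds 1 and 3 differ only in the configuration as drawn.

Going by these compounds, whether inverting only one of the two stereocentres would behave the same stays open. So does whether mirror images stay this close when the shared core carries another group, such as an amine or a carboxylic acid.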